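Solubility Outlook for an Aryl Swap on a Shared Core

This account rests on a few compounds, and the source may have more. Where it says the series, first, only, none or still open, it means among the compounds named here.

Compound 1 `COc1ccc(-c2cnn3c(NCc4ccccn4)cc(C)nc23)cc1`: < 5000 nM
Compound 2 `Cc1cc(NCc2ccccn2)n2ncc(-c3cccc(Cl)c3)c2n1`: < 5000 nM

In a physicochemical assay for solubility, read by HPLC, using the shake flask method, measured as kinetic solubility, with a stated time of 2 h, at pH 7.4 (on this read-out higher numbers stand for higher solubility and lower numbers for lower solubility), compound 1 gives only a limit, < 5000 nM. In this assay compound 2 likewise gives only a limit, < 5000 nM. Within the data shown here, the one measured step, a step that the two limits leave unreadable from compound 1 to compound 2, therefore cannot be sized, and the limit of < 5000 nM in this assay, at which 2 of the 2 values shown sit, is all the evidence there is. Compound 3 `Cc1cc(NCc2ccccn2)n2ncc(-c3ccccc3C)c2n1` differs from compound 2 by 2-methylphenyl in place of 3-chlorophenyl on an aromatic carbon. With no readable step to lean on, compound 3 is expected to sit at a similar limit, estimated at 2000 nM, between 300 nM and 5000 nM. The expected step from compound 2 to compound 3 is a step that the limit leaves unreadable from compound 2 to compound 3.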

Compound 3, solubility: < 5000 nM
Compound 3: a limit, no number (the forecaster's own chance of this, stated with the estimate: 75%); the middle value does not contradict the limit.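

Among these compounds, no step among compound 1, compound 2 and compound 3 can be read, since each gives only a limit: the limit of < 5000 nM in this assay, at which 3 of the 3 values shown sit.

On these data alone, how much solubility each compound truly has, and whether swapping the group on the shared core changes it, stays open.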